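Replacing a diethylamino group with isopropylamino on an amide

The compounds below may be only part of what the source reports. "The series", "measured", "known", "first", "only" and "open" are said of these compounds alone.

Compound 1 `COc1cc2c(cc1OC)C(CC(N)=O)CC2` and compound 2 `CCN(CC)C(=O)CC1CCc2cc(OC)c(OC)cc21` share one core and differ only at the amide nitrogen. In a functional assay on the whole organism (strain Wistar) for inhibition, with Rattus norvegicus as the target, read by paw edema, with stated times of 60 min and 2 h, at a dose of 100 mg/kg by the oral route (on this read-out lower numbers stand for less inhibition and higher numbers for more inhibition at the one dose given (going by the name of the read-out)), compound 1 gives 31%, while compound 2 gives 40%. The change a number 9 percentage points higher from compound 1 to compound 2 (within the scatter) is small. Among the two numbers measured, compound 2 holds the higher one, but its nearest neighbour, compound 1, is within the scatter, so no order can be claimed between them.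

Compound 3 `COc1cc2c(cc1OC)C(CC(=O)NC(C)C)CC2` is the next variation: isopropylamino in place of diethylamino on a carbonyl carbon. Going by the values given here, the only step that bears on it is the one at the same amide nitrogen, a number 9 percentage points higher from compound 1 to compound 2 (within the scatter), which stayed within the scatter. A change at this position is therefore expected to move this assay little in either direction. The step of a number 4 percentage points lower from compound 2 to compound 3 (within the scatter) is estimated to stay within the scatter. For compound 3 the expected value is 36%, with a range from 22% to 50%.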

Compound 3, a percentage reported as inhibition, in the whole organism at one dose (the size of the read-out at that dose, not a potency): 37%
For compound 3 the middle estimate is 1 percentage points below the measured one; the range from low to high includes it.
By their numbers in this assay, from the lowest: compounds 1, 3 and 2 (each within the scatter of the next).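

Setting isopropylamino in place of diethylamino at the amide nitrogen, which adds back one hydrogen-bond donor, gives in this assay a number 3 percentage points lower from compound 2 to compound 3 (within the scatter), and isopropyl in place of hydrogen on the same nitrogen gives a number 6 percentage points higher from compound 1 to compound 3 (within the scatter). With the earlier step, all three pairs at this position now lie within the scatter, so the plain amide, the isopropylamide and the diethylamide cannot be put in any order. Nothing on hand gives a reason for these numbers.

Still open, from the compounds shown here alone, is whether a larger change on the carbonyl carbon, such as a piperidine ring on the amide nitrogen or a carboxylic acid in place of the amide, would move the number beyond the scatter. Going by these compounds, the effect of a longer chain on that nitrogen also remains unknown.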